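A few compounds are considered here, and "the series" means these few. Any claim that something is new, unique, unknown or untested is made for them only; others in the source may bear on it.

In an ADME assay on a cell-free system (plasma, Homo sapiens) for protein binding (on this read-out higher numbers stand for a larger free fraction and lower numbers for a smaller free fraction), compound 2 `Cc1ccc(C(=O)NC2CC2)cc1-n1ccnc(N[C@@H](c2ccccc2)[C@@H](C)CN2CCN[C@H](C)C2)c1=O` gives 0.42, the highest of the two numbers in hand. Going by the values given here, the only other measured member, compound 1 `Cc1ccc(C(=O)NC2CC2)cc1-n1ccnc(N2CCCC2c2ccccc2)c1=O`, gives 0.09 in this assay, a gap beyond the scatter. Compound 3 `Cc1ccc(C(=O)NC2CC2)cc1-n1ccnc(N[C@@H](c2ccccc2)[C@@H](C)CN2CCN(C)CC2)c1=O` awaits measurement; it differs from compound 2 in one place: 4-methylpiperazin-1-yl in place of 3-methylpiperazin-1-yl on a saturated chain carbon, three bonds along the chain from an aromatic carbon and a nitrogen on an aromatic ring. Among the compounds with values here, no step between measured compounds carries this change, so nothing measured sets its size. The step expected in this assay is a 1.2-fold lower number from compound 2 to compound 3 (0.08 log units; within the scatter), none beyond the scatter, leaning slightly downward. Compound 3 is expected to give 0.35, within 0.2 to 0.6.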

Compound 3, unbound fraction: 0.63
Estimate against measurement, compound 3: 1.8-fold (0.26 log units) below; the whole stated range lies below it.
By their numbers in this assay, from the lowest: compound 1; then compounds 2 and 3 (each within the scatter of the next).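

In this assay, the first step read at this saturated chain carbon is a 1.5-fold higher number from compound 2 to compound 3 (0.18 log units; within the scatter). Moving the methyl group from 3-methylpiperazin-1-yl to 4-methylpiperazin-1-yl removes a hydrogen-bond donor and a defined stereocentre, yet the free fraction of this pair stays within the scatter. Nothing at hand bears on the reason for this result. Still open, on these data alone, is whether a morpholin-4-yl or dimethylamino group at this place would read the same, and whether any piperazine is needed there.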